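The source may hold more compounds than are shown below. What is called first, only, known or untested is meant among the compounds shown, and "the series" means these compounds.

In an ADME assay on microsomes from liver (Homo sapiens) for metabolic stability, read by HPLC, using NADPH, with a stated time of 60 min, tested at 1 uM, in the presence of a further agent that is not named here (a higher number here means that the compound lasts longer, a lower number that the compound disappears faster), three compounds have been measured so far. Compound 1 (`O=C(NNS(=O)(=O)c1ccccc1F)c1cc(F)cc(-c2ccccn2)c1`) gives 0.933 h, compound 2 (`Cc1cc(-c2ncccn2)cc(C(=O)NNS(=O)(=O)c2ccccc2)c1F`) gives 2.72 h, and compound 3 (`Cc1cc(-n2cccn2)cc(C(=O)NNS(=O)(=O)c2ccccc2)c1F`) gives 1.25 h. Compound 3 thus lies within the usual scatter of compound 1 but beyond the scatter from compound 2.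

Compound 4 (`Cc1cc(-c2ccccn2)cc(C(=O)NNS(=O)(=O)c2ccccc2)c1F`) keeps the core of compound 3 and has pyridin-2-yl in place of 1H-pyrazol-1-yl on an aromatic carbon.

Within the data shown here, the only measured step at this place is a 2.2-fold lower number from compound 2 to compound 3 (0.34 log units; beyond the scatter), a modest change that swapped pyrimidin-2-yl for 1H-pyrazol-1-yl. It suggests that this group can matter on this core. Compound 1 also carries pyridin-2-yl, but its core differs, so its 0.933 h is only a loose guide.

Taking both together, a small rise is expected, with an estimated step of a 1.3-fold higher number from compound 3 to compound 4 (0.11 log units; within the scatter), which would stay within the scatter. The half-life of compound 4 is estimated at 1.6 h, with an expected range from 0.8 h to 3.2 h.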

Compound 4, half-life: 1.08 h
Compound 4: the middle estimate sits 1.5-fold (0.17 log units) above what was measured; the range from low to high includes it.
By their numbers in this assay, from the lowest: compounds 1, 4 and 3 (each within the scatter of the next); then compound 2.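

On the shared core in this assay, pyridin-2-yl in place of 1H-pyrazol-1-yl gives a 1.2-fold lower number from compound 3 to compound 4 (0.06 log units; within the scatter), so this assay does not separate these two groups at this position. Pyrimidin-2-yl now stands apart from both of them, since pyridin-2-yl in its place gives a 2.5-fold lower number from compound 2 to compound 4 (0.40 log units; beyond the scatter), in line with the earlier 2.2-fold lower number from compound 2 to compound 3 (0.34 log units; beyond the scatter), so the one earlier step at this position no longer rests on a single partner. No supporting data are available to explain why pyrimidin-2-yl stands apart.

The compounds shown leave open how an amine, a carboxylic acid or a morpholine ring would behave at this position, as all three groups here are aromatic rings. They also leave open whether pyrimidin-2-yl would stand apart in the same way on the core of compound 1.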